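The source may hold more compounds than are shown below. What is called first, only, known or untested is meant among the compounds shown, and "the series" means these compounds.

Measured in an ADME assay on L929 cells (Mus musculus, culture collection number NCTC 929) for cytotoxicity, read by MTT assay, with a stated time of 72 h; on this read-out lower numbers stand for stronger inhibition and higher numbers for weaker inhibition
compound 1 `Cc1cc(O)c(C(=O)NCCCc2ccccc2)c(=O)o1` gives 143000 nM on this read-out
compound 2 `CCCCCCCCCCCCc1c(O)cc(C)oc1=O` gives 57200 nM on this read-out

Compound 1 has the higher of the two numbers, and compound 2 lies below it by a gap beyond the usual scatter. Compound 3 `CCCCCCNC(=O)c1c(O)cc(C)oc1=O` is not yet measured. It differs from compound 1 by propyl in place of phenyl on a saturated chain carbon, three bonds along the chain from an amide-type nitrogen. For the measured compounds named here, no measured pair shows this change alone, and compounds 1 and 2 differ by more than this one change, so the evidence is thin. In this assay no step beyond the scatter is expected, with only a slight lean towards a lower number. The estimated 1.3-fold lower number from compound 1 to compound 3 (0.11 log units; within the scatter) is therefore small. For compound 3 the estimated value is 110000 nM with an expected range from 50000 nM to 230000 nM on this read-out.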

Compound 3, half-maximal inhibitory concentration: 196000 nM
Compound 3: middle estimate off by 1.8-fold (0.25 log units), on the low side, and the stated range covers the measured number.
By their numbers in this assay, from the lowest: compound 2; then compounds 1 and 3 (each within the scatter of the next).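

In this assay, for the compounds shown here, the swap of phenyl for propyl on a saturated chain carbon, three bonds along the chain from an amide-type nitrogen, gives a 1.4-fold higher number from compound 1 to compound 3 (0.14 log units; within the scatter) and is the first matched change read at this position. The six-membered aromatic ring of carbon at the end of the chain can therefore be replaced by an open propyl end without a step beyond the scatter on the shared core. No measurement shown here accounts for this result.

On these data alone, whether an amine, a carboxylic acid or a longer chain at this place would give a step beyond the scatter remains open. For compound 2 at 57200 nM no single change from compound 1 or compound 3 can be read, so what separates its value from theirs also stays unresolved.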